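Fluoro to Methoxy Swap and Fibroblast Cytotoxicity

The compounds below may be only part of what the source reports. "The series", "measured", "known", "first", "only" and "open" are said of these compounds alone.

Three compounds have so far been measured in an ADME assay on cells (Fibroblast, Homo sapiens) for cytotoxicity, with a stated time of 48 h; a higher number here means a weaker inhibitor, a lower number a stronger inhibitor:

Compound 1 `O=[N+]([O-])c1ccc(CN2CCC(n3cc(CC(OCc4cc(-c5cccc(F)c5)no4)c4ccc(Br)cc4)nn3)CC2)cc1` gives 10000 nM.
Compound 2 `COc1cccc(-c2cc(COC(Cc3cn(C4CCN(Cc5ccc([N+](=O)[O-])cc5)CC4)nn3)c3ccc(Br)cc3)on2)c1` gives > 25000 nM, which is a limit of the assay and not a number.
Compound 3 `O=[N+]([O-])c1ccc(CN2CCC(n3cc(CC(OCc4cc(-c5ccccc5F)no4)c4ccc(Br)cc4)nn3)CC2)cc1` gives > 25000 nM, which is likewise a limit of the assay.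

Compound 2 differs from compound 1 by methoxy in place of fluoro on an aromatic carbon. This change gives an at least 2.5-fold higher number from compound 1 to compound 2 (0.39 log units; beyond the scatter). Compound 3 is built from the same atoms as compound 1, joined differently: 2-fluorophenyl in place of 3-fluorophenyl on an aromatic carbon. That rearrangement gives an at least 2.5-fold higher number from compound 1 to compound 3 (0.39 log units; beyond the scatter). Between the other two, the step is a step that the two limits leave unreadable from compound 2 to compound 3. Two of the three values sit at the limit of > 25000 nM in this assay, at which 2 of the 3 values shown sit.

Compound 4 `COc1ccccc1-c1cc(COC(Cc2cn(C3CCN(Cc4ccc([N+](=O)[O-])cc4)CC3)nn2)c2ccc(Br)cc2)on1` has not yet been measured. It differs from compound 3 by methoxy in place of fluoro on an aromatic carbon. Going by the values given here, this is the same kind of change as the one from compound 1 to compound 2, but the place is not identical: in compound 2 the methoxy sits meta to a large group, whereas in compound 4 it sits ortho to a large group. The earlier change weakened the inhibitor at least modestly, and compound 3 already stands at a limit.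

Because compound 3 sits at the limit of > 25000 nM in this assay, at which 2 of the 3 values shown sit, compound 4 is expected to stay at or beyond that limit as well. Compound 4 is estimated to give 35000 nM, with an expected range from 15000 nM to 90000 nM. The expected step is a step that the limit leaves unreadable from compound 3 to compound 4, most likely again reported only as a limit.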

Compound 4, half-maximal inhibitory concentration: > 25000 nM
Compound 4: a limit, no number (the forecaster's own chance of this, stated with the estimate: 80%); the middle value is on the limit's open side.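

In this assay compound 4 gives > 25000 nM, which is a limit of the assay and not a number. Methoxy in place of fluoro gave an at least 2.5-fold higher number from compound 1 to compound 2 (0.39 log units; beyond the scatter), but the same change cannot be followed from the 2-fluorophenyl to the 2-methoxyphenyl compound, and none of the steps among compound 2, compound 3 and compound 4 can be read, since each of these compounds stands at the same limit: the limit of > 25000 nM in this assay, at which 3 of the 4 values shown sit. The one readable new comparison is an at least 2.5-fold higher number from compound 1 to compound 4 (0.39 log units; beyond the scatter), which places compound 4 with compound 2 and compound 3 on the far side of compound 1, so the result is consistent with the methoxy change carrying over without lowering the number, yet it does not show that this change itself raises the number in the second setting, or by how much.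

With compound 1 the only one of the four to carry a number, the compounds shown leave open how far beyond the limit any of the other three lies. They also leave open whether an unsubstituted phenyl, or an amine or a carboxylic acid on that ring, would give a value that can be read as a number, which would allow a size to be put on such steps.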